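Linker shortening at the basic side chain of compound 2

The compounds below may be only part of what the source reports. "The series", "measured", "known", "first", "only" and "open" are said of these compounds alone.

Measured in a functional assay on NCI-H460 cells (Homo sapiens) for cytotoxicity, read by MTT assay, with a stated time of 72 h; on this read-out lower numbers stand for stronger inhibition and higher numbers for weaker inhibition:
compound 1 `CN(C)CCNc1nc(-c2ccc(NC(=O)Nc3ccc(Cl)cc3)cc2)nc2c(Cl)c(Cl)sc12`: 300 nM
compound 2 `CCN(CC)CCCNc1nc(-c2ccc(NC(=O)Nc3ccc(Cl)cc3)cc2)nc2c(Cl)c(Cl)sc12`: 270 nM
compound 3 `CCN(CC)CCCNc1nc(-c2ccc(NC(=O)Nc3ccc(C)cc3)cc2)nc2c(Cl)c(Cl)sc12`: 1240 nM

Compound 2 shows the lowest number of the three, but its gap to compound 1 is within the scatter (a 1.1-fold lower number from compound 1 to compound 2 (0.05 log units; within the scatter)), so the two cannot be ordered against each other; only compound 3 stands apart, with a 4.6-fold higher number from compound 2 to compound 3 (0.66 log units; beyond the scatter) on exchange of the substituent at the urea end.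

Compound 4 `CCN(CC)CCNc1nc(-c2ccc(NC(=O)Nc3ccc(Cl)cc3)cc2)nc2c(Cl)c(Cl)sc12` is the unmeasured neighbour of compound 2. The change is diethylamino in place of (diethylamino)methyl on a saturated chain carbon, two bonds along the chain from a nitrogen on an aromatic ring. The urea portion, the shared core and the terminal diethylamino group are kept; only the chain between the aromatic nitrogen and the basic nitrogen is shortened.

Within the data shown here, one measured step touches this side chain, a 1.1-fold lower number from compound 1 to compound 2 (0.05 log units; within the scatter), and there the chain was lengthened while dimethylamino was replaced by diethylamino in the same move; the combined change moved nothing beyond the scatter. The step from compound 2 to compound 4 reverses the chain part alone. Among the measured compounds shown here, no step that separates chain length from amine size is available. The expectation in this assay is therefore no change beyond the scatter, a 1.1-fold higher number from compound 2 to compound 4 (0.05 log units; within the scatter). Compound 4 is estimated at 300 nM, with a range from 140 nM to 650 nM.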

Compound 4, half-maximal inhibitory concentration: 320 nM
Beside the measured number, compound 4's estimate is 1.1-fold (0.03 log units) below it; the measured number falls inside the stated range.
By their numbers in this assay, from the lowest: compounds 2, 1 and 4 (each within the scatter of the next); then compound 3.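

In this assay, among these compounds, 3-(diethylamino)propyl gives way to 2-(diethylamino)ethyl with the terminal diethylamino group kept, and this gives a 1.2-fold higher number from compound 2 to compound 4 (0.07 log units; within the scatter) with nothing else altered, so the chain is read on its own for the first time and this shortening stays within the scatter. With the 2-carbon chain held, diethylamino in place of dimethylamino gives a 1.1-fold higher number from compound 1 to compound 4 (0.03 log units; within the scatter) and also stays within the scatter, so the two parts of the earlier combined step are now separated and neither part alone moves the number beyond the scatter. No measurement available here bears on why these three compounds stay so close.

The compounds shown leave open whether a longer chain such as 4-(diethylamino)butyl, or a ring amine such as morpholine or piperidine in place of diethylamino, would stay within the scatter of these values. Among the compounds shown here, they also leave open whether the same insensitivity to the side chain holds when methyl replaces chloro at the urea end, since compound 3 is the only methyl compound among them.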